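Mirror-image pair at the assay limit

The source may report more compounds than this note shows. Statements on the series, on what has been measured and on what is new or still open speak of the compounds shown alone.

Measured compounds in an ADME assay on MCF-10A cells (Homo sapiens) for antiproliferative activity, read by sulforhodamine B assay, with a stated time of 48 h; a higher number here means a weaker inhibitor, a lower number a stronger inhibitor:
compound 1 `CC1(C)[C@@H]2CC3=N[C@@H](CCC(=O)O)C(=O)O[C@@]3(C)[C@H]1C2` — compound 1 gives > 1200000 nM, a limit of the assay and not a number.
compound 2 `C[C@@H]1N=C2C[C@@H]3C[C@@H](C3(C)C)[C@]2(C)OC1=O` — compound 2 gives > 2000000 nM, a limit of the assay and not a number.
compound 3 `CC(C)(C)OC(=O)CC[C@H]1N=C2C[C@H]3C[C@H](C3(C)C)[C@@]2(C)OC1=O` — compound 3 gives > 1200000 nM, a limit of the assay and not a number.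

Compound 3 thus stands only at a limit in this assay; its value is the limit of > 1200000 nM in this assay, at which 2 of the 3 values shown sit, and no number for it is known. Compound 4 `CC(C)(C)OC(=O)CC[C@@H]1N=C2C[C@@H]3C[C@@H](C3(C)C)[C@]2(C)OC1=O` differs from compound 3 in configuration only: the two compounds have the same atoms and bonds and differ only in configuration as drawn: 4 of 4 stereo elements differ (all stereocentres are inverted: mirror images); a stereocentre at a saturated ring carbon is drawn R in compound 3 and S in compound 4; a stereocentre at a saturated ring carbon is drawn R in compound 3 and S in compound 4; a stereocentre at a saturated ring carbon is drawn R in compound 3 and S in compound 4; a stereocentre at a saturated ring carbon is drawn R in compound 3 and S in compound 4.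

Among the measured compounds shown here, the single measured step, a step that the two limits leave unreadable from compound 1 to compound 2, runs between two limits and cannot be read; it concerns a change of substituent, not of configuration, so it does not bear on the step to compound 4. Compound 2 sits at the limit of > 2000000 nM in this assay, at which 1 of the 3 values shown sits, which adds nothing readable either. For the measured compounds named here, no measured step in this assay speaks to an inversion of all stereocentres.

With every compound at a limit, compound 4 is expected to remain at the limit as well, so the step of a number no higher from compound 3 to compound 4 (the limit leaves the size open) is expected to be none beyond the scatter. For compound 4 the estimate is 1200000 nM, with a range from 300000 nM to 3000000 nM.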

Compound 4, half-maximal inhibitory concentration: > 1000000 nM
Compound 4: no number, only a limit (the forecaster's own chance of this, stated with the estimate: 80%); the middle value is on the limit's open side.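

In this assay compound 4 gives > 1000000 nM, a limit of the assay and not a number. Its steps to compound 1, compound 2 and compound 3 all run between two limits and cannot be read. From the compounds shown here alone, whether the mirror images compound 3 and compound 4 differ at all in this assay stays open.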